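This account rests on a few compounds, and the source may have more. Where it says the series, first, only, none or still open, it means among the compounds named here.

Working notes on the series in a toxicity assay on NIH3T3 cells (Mus musculus) for cytotoxicity, read by resazurin assay; on this read-out higher numbers stand for an effect only at larger amounts of compound and lower numbers for an effect already at smaller amounts. Compound 2 `Cc1cccc(-c2cccc(NCc3cncn3Cc3ccccc3)c2)c1` stands only at a limit of the assay: in this assay compound 2 gives > 1000 nM, a limit and not a number. Compound 1 `Cc1cccc(-c2cccc(NCc3cncn3Cc3ccccc3)c2)c1C` also stands at a limit: in this assay compound 1 gives > 1000 nM. For compound 3 `COC(=O)c1ccc(NCc2cncn2Cc2ccc(OC)cc2)cc1-c1ccccc1` the read-out in this assay is "not determined" (no result reported). Within the data shown here, the one step between measured compounds, a step that the two limits leave unreadable from compound 1 to compound 2, hydrogen in place of methyl on an aromatic carbon, cannot be sized because the limit of > 1000 nM in this assay, at which 2 of the 3 values shown sit, holds both of its ends. Compound 4 `c1ccc(Cn2cncc2CNc2cccc(-c3cccnc3)c2)cc1` is not yet measured in this assay. Its change from compound 2 is pyridin-3-yl in place of 3-methylphenyl on an aromatic carbon. Among the measured compounds shown here, no measured step bears on this change in a readable way, and the two values shown sit at the same limit. The step from compound 2 to compound 4 in this assay is therefore expected to be none beyond the scatter, estimated as a step that the limit leaves unreadable from compound 2 to compound 4. Compound 4 is expected to give 3000 nM in this assay, with a range from 800 nM to 20000 nM, and most likely to be reported again only as a limit.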

Compound 4, half-maximal effective concentration: > 1000 nM
Compound 4 ended at the assay's limit (the forecaster's own chance of this, stated with the estimate: 85%); the middle value lies beyond the limit too.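

Among these compounds, no step among compound 1, compound 2 and compound 4 can be read in this assay, because the values of all three are limits and not numbers: the limit of > 1000 nM in this assay, at which 3 of the 4 values shown sit. On these data alone, whether pyridin-3-yl, 3-methylphenyl or 2,3-dimethylphenyl differ at all in this read-out stays open.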